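Carbonyl substituent variation: from compound 2 to compound 4

The compounds below may be only part of what the source reports. "The series", "measured", "known", "first", "only" and "open" are said of these compounds alone.

Three members of the series have been measured in an ADME assay on BHK15 cells (Mesocricetus auratus) for inhibition, read by XTT assay, with a stated time of 36 h; a higher number here means a weaker inhibitor of growth, a lower number a stronger inhibitor of growth. Compound 1 `CN(C)C(=O)c1sc(-c2ccc(Cl)cc2)nc1C(Br)Br` gives 163000 nM, compound 2 `CCN(CC)C(=O)c1sc(-c2ccc(Cl)cc2)nc1C(Br)Br` gives 63500 nM, and compound 3 `CC(C)OC(=O)c1sc(-c2ccc(Cl)cc2)nc1C(Br)Br` gives 372000 nM. Compound 2 holds the lowest number of the three, both of its steps lying beyond the scatter. Compound 4 `CN(C)/C=C/C(=O)c1sc(-c2ccc(Cl)cc2)nc1C(Br)Br` differs from compound 2 in one place: 2-(dimethylamino)ethenyl in place of diethylamino on a carbonyl carbon. All measured steps alter the group on the carbonyl carbon and are modest: a 2.6-fold lower number from compound 1 to compound 2 (0.41 log units; beyond the scatter), a 2.3-fold higher number from compound 1 to compound 3 (0.36 log units; beyond the scatter) and a 5.9-fold higher number from compound 2 to compound 3 (0.77 log units; beyond the scatter). None exchanges diethylamino for a group holding a double bond, so they bear only loosely; a modest step toward a higher number is expected in this assay, namely a 1.7-fold higher number from compound 2 to compound 4 (0.24 log units; within the scatter). Compound 4 is estimated at 110000 nM, within 30000 nM to 400000 nM.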

Compound 4, concentration for 50% growth inhibition: 38200 nM
For compound 4 the middle estimate is 2.9-fold (0.46 log units) above the measured one; the measured number falls inside the stated range.
By their numbers in this assay, from the lowest: compounds 4 and 2 (each within the scatter of the next); then compound 1; then compound 3.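

In this assay, a carbon-linked 2-(dimethylamino)ethenyl group on the carbonyl carbon sits level with diethylamino (a 1.7-fold lower number from compound 2 to compound 4 (0.22 log units; within the scatter)), so the low end of the series is no longer held by an amide alone. Compound 4 also separates clearly from the other two (a 4.3-fold lower number from compound 1 to compound 4 (0.63 log units; beyond the scatter); a 9.7-fold lower number from compound 3 to compound 4 (0.99 log units; beyond the scatter)). Nothing at hand accounts for this result.

The compounds shown leave open whether the double bond or the terminal dimethylamino matters here; a saturated 2-(dimethylamino)ethyl group on the carbonyl carbon would separate the two.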